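The source may report more compounds than this note shows. Statements on the series, on what has been measured and on what is new or still open speak of the compounds shown alone.

Of the compounds shown here, three of a shared core have been measured in a physicochemical assay for acid dissociation, and a fourth awaits its turn. Compound 1 `Fc1ccc(-c2ccc3c(NCCCNCc4ccco4)ccnc3c2)cc1` carries a 4-fluorophenyl group on the core and a (furan-2-yl)methyl group on the amine at the far end of the chain; in this assay compound 1 gives 9.47. Compound 2 `CN(C)c1cccc(Oc2ccc3c(NCCCNCc4ccco4)ccnc3c2)c1` differs from compound 1 by 3-(dimethylamino)phenoxy in place of 4-fluorophenyl on an aromatic carbon, and in this assay compound 2 gives 9.28, so the step is a number 0.19 log units lower from compound 1 to compound 2 (within the scatter). Compound 3 `COc1ccc(F)cc1CNCCCNc1ccnc2cc(-c3ccc(F)cc3)ccc12` differs from compound 1 at the other end, by 5-fluoro-2-methoxyphenyl in place of furan-2-yl on a saturated chain carbon bound to an amine nitrogen; in this assay compound 3 gives 9.47, a step of no change at the digits printed from compound 1 to compound 3 (within the scatter).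

Compound 4 `COc1ccc(F)cc1CNCCCNc1ccnc2cc(Oc3cccc(N(C)C)c3)ccc12` is still to be measured. It differs from compound 3 by 3-(dimethylamino)phenoxy in place of 4-fluorophenyl on an aromatic carbon. This is the same change that turns compound 1 into compound 2, made at the same place and in the same words, only now on a core that carries the 5-fluoro-2-methoxybenzyl group instead of the (furan-2-yl)methyl group. Because that earlier change gave a number 0.19 log units lower from compound 1 to compound 2 (within the scatter), and because compound 3 stands at 9.47, the step from compound 3 to compound 4 is expected to be about as small, a number 0.17 log units lower from compound 3 to compound 4 (within the scatter). Within the data shown here, the expectation for compound 4 in this assay is therefore 9.3, with a range from 8.9 to 9.7, resting on only one earlier example of this change.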

Compound 4, acid dissociation constant: 9.28
For compound 4 the middle estimate is 0.02 log units above the measured one; the measured number falls inside the stated range.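

In this assay, putting 3-(dimethylamino)phenoxy in place of 4-fluorophenyl gives a number 0.19 log units lower from compound 3 to compound 4 (within the scatter), the same size at the digits printed as a number 0.19 log units lower from compound 1 to compound 2 (within the scatter), while 5-fluoro-2-methoxyphenyl in place of furan-2-yl gives no change at the digits printed from compound 2 to compound 4 (within the scatter), so each of the two changes reads alike on both cores in this set of four compounds. Every one of these steps lies within the scatter, so the result shows that the change stayed inside the ordinary noise of the measurement on both cores; it does not show a real effect that carries from one core to the other, and one pair of cores sets no rule for the whole series. Nothing given here speaks to why the numbers came out this way.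

The compounds shown offer only two groups at each of the two places, so it remains open whether the same agreement would hold for a step large enough to stand clear of the scatter. A carboxylic acid on the aromatic carbon, a morpholine in place of the dimethylamino group, or a longer chain carrying the far amine could each test that question.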